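The compounds below may be only part of what the source reports. "The series", "measured", "known", "first", "only" and "open" are said of these compounds alone.

Working notes on the series.

Compound 2 `C=C(Br)C(=O)Nc1cccc(-c2cn3nc(-c4ccc(Cl)cc4)sc3n2)c1` in a functional assay on FM3A cells (Mus musculus) for inhibition, read by cell counting, with a stated time of 2 days (a lower number here means a stronger inhibitor, a higher number a weaker inhibitor), gives 2000 nM. Among the three numbers so far it stands second highest; its nearest neighbour is compound 1 `C=C(Br)C(=O)Nc1cccc(-c2cn3nc(-c4ccc(OCC)cc4)sc3n2)c1`, which gives 1100 nM, and its furthest is compound 3 `Nc1cccc(-c2cn3nc(-c4ccc(Cl)cc4)sc3n2)c1`, which gives 160000 nM. The change a 1.8-fold higher number from compound 1 to compound 2 (0.26 log units; within the scatter) involves chloro in place of ethoxy on an aromatic carbon; the change an 80-fold higher number from compound 2 to compound 3 (1.90 log units; beyond the scatter) involves hydrogen in place of (1-bromoethenyl)carbonyl on a nitrogen on an aromatic ring.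

The next compound, compound 4 `C=C(Br)C(=O)Nc1cccc(-c2cn3nc(-c4cccc(OC)c4)sc3n2)c1`, differs from compound 2 as follows: 3-methoxyphenyl in place of 4-chlorophenyl on an aromatic carbon. Among the measured compounds shown here, the step that bears on it is the one from compound 1 to compound 2, where a different group on the same aromatic carbon moved the number only within the scatter. For the measured compounds named here, no measured step covers the methoxy group or its placement on the ring, so that part of the change is uncharted. The (1-bromoethenyl)carbonyl group, whose removal gave the large step, is retained.

On this basis a step of a 1.3-fold lower number from compound 2 to compound 4 (0.12 log units; within the scatter) is expected, that is, no change beyond the scatter. Compound 4 is estimated at 1500 nM, with a range from 500 nM to 5000 nM.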

Compound 4, half-maximal inhibitory concentration: 500 nM
Estimate against measurement, compound 4: 3.0-fold (0.48 log units) above; the measured number falls inside the stated range.
By their numbers in this assay, from the lowest: compound 4; then compounds 1 and 2 (each within the scatter of the next); then compound 3.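

In this assay this position, the aromatic carbon next to the ring nitrogen and the ring sulfur, now shows steps beyond the scatter: a 4.0-fold lower number from compound 2 to compound 4 (0.60 log units; beyond the scatter) and a 2.2-fold lower number from compound 1 to compound 4 (0.34 log units; beyond the scatter) with 3-methoxyphenyl entering in place of 4-chlorophenyl and 4-ethoxyphenyl. The earlier exchange of chloro for ethoxy on this phenyl ring stayed within the scatter, whereas this change, which alters both the substituent and its placement, gives a modest gain. Nothing measured here bears on the reason for that gain.

From the compounds shown here alone, it remains open whether the gain belongs to the methoxy group or to its placement on the ring; the two change together in compound 4. Also open, going by these compounds, is how an amine, a carboxylic acid or a longer alkoxy chain such as butoxy would fare on this phenyl ring.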